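From ureido to hydroxy on the double-bonded nitrogen

A few compounds are considered here, and "the series" means these few. Any claim that something is new, unique, unknown or untested is made for them only; others in the source may bear on it.

Three related compounds have been measured so far. In a functional assay on HCT-116 cells (Homo sapiens) for inhibition, read by sulforhodamine B assay, with a stated time of 48 h, tested at 50 uM (a lower number here means less inhibition of growth, a higher number more inhibition of growth at the concentration tested), compound 1 `CCCOc1ccc([C@@H]2CC(=O)c3cc(CC=C(C)C)c(OC)cc3O2)cc1` gives 63% and compound 2 `COc1ccc([C@@H]2C/C(=N/OCc3cn(-c4ccc(C(=O)c5ccccc5)cc4)nn3)c3cc(CC=C(C)C)c(OC)cc3O2)cc1` gives 52% at the concentration tested. Compound 3 `COc1cc2c(cc1CC=C(C)C)/C(=N/NC(N)=O)C[C@@H](c1ccc(O)cc1)O2` gives 87% and so stands highest of the three, above both others by more than the usual scatter. Among the measured compounds shown here, these three differ in more than one place, so no measured pair isolates a single change.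

The next compound stays close to compound 3. Compound 4 `COc1cc2c(cc1CC=C(C)C)/C(=N/O)C[C@@H](c1ccc(O)cc1)O2` carries hydroxy in place of ureido on a double-bonded nitrogen and is otherwise the same.

For the measured compounds named here, with no measured step for this change, any expectation remains loose. Going by the values given here, compound 3 at 87% already sits high, while compound 2 at 52%, the only other measured compound with an oxygen on the double-bonded nitrogen, sits lower, which points to a fall rather than a rise. The step expected in this assay is downward and modest, estimated as a number 13 percentage points lower from compound 3 to compound 4 (beyond the scatter) here. For compound 4 the expected value is 74% within an estimated range of 55% to 92% in this reading.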

Compound 4, percent growth inhibition at one concentration: 99%
Estimate against measurement, compound 4: 25 percentage points below; the whole stated range lies below it.
By their numbers in this assay, from the lowest: compound 2; then compound 1; then compound 3; then compound 4.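

In this assay, among the compounds shown here, the change from ureido to hydroxy gives a number 12 percentage points higher from compound 3 to compound 4 (beyond the scatter) and is the only measured change here confined to one place, so it is the first direct reading of a group on the double-bonded nitrogen. It shows that the four heavy atoms of ureido, with its carbon, two nitrogens and oxygen, are not required for growth inhibition at the concentration tested, since the single oxygen of hydroxy does not lower the number but raises it modestly, by more than the usual scatter. Nothing available here accounts for this rise.

For the compounds shown here, with only this one step at this position, it remains open whether the rise is particular to hydroxy or would also appear with a methoxy or an amino group on the double-bonded nitrogen. Both compounds are also compared at a single concentration in one cell line, so the reading leaves open how far they would separate at lower concentrations or in other cells.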